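A few compounds are considered here, and "the series" means these few. Any claim that something is new, unique, unknown or untested is made for them only; others in the source may bear on it.

Of the compounds shown here, two have been measured in a functional assay on A549 cells (Homo sapiens) for inhibition, read by MTT assay, with a stated time of 48 h (on this read-out lower numbers stand for stronger inhibition and higher numbers for weaker inhibition), so far. Compound 1, whose structure is `Cc1nc(N(C)c2ccc([Se]C#N)c(Cl)c2)c2ccccc2n1`, gives 7 nM in this assay. Compound 2, with the structure `COc1ccc(N(C)c2nc(C)nc3ccccc23)cc1C(=O)NCC[Se]C#N`, gives 187 nM in this assay, the higher of the two numbers, so it stands as the weaker inhibitor of the pair, and the gap to compound 1 lies well beyond the ordinary scatter of repeat measurements.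

The step now considered leads from compound 2 to compound 3, whose structure is `COc1ccc(N(C)c2nc(C)nc3ccccc23)cc1[Se]C#N`. The change is a group of 3 heavy atoms (1 carbon, 1 nitrogen, 1 selenium; no ring) in place of a group of 8 heavy atoms (4 carbon, 2 nitrogen, 1 oxygen, 1 selenium; no ring), on an aromatic carbon, and it brings compound 3 closer in build to compound 1, which carries its selenium group directly on the aromatic ring as well. Since compound 1 gives 7 nM in this assay, a move toward its arrangement is expected to lower the number. Compound 3 is therefore expected to show a step of a 6.2-fold lower number from compound 2 to compound 3 (0.79 log units; beyond the scatter) in this assay, a drop beyond the scatter. The estimate for compound 3 in this assay is 30 nM, with a likely range from 8 nM to 120 nM.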

Compound 3, half-maximal inhibitory concentration: 49 nM
For compound 3 the middle estimate is 1.6-fold (0.21 log units) below the measured one; the measured number falls inside the stated range.
By their numbers in this assay, from the lowest: compound 1; then compound 3; then compound 2.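

In this assay, replacing the group of 8 heavy atoms, which holds the amide hydrogen, with the group of 3 heavy atoms (1 carbon, 1 nitrogen, 1 selenium) on the same aromatic carbon, ortho to a methoxy group, gives a 3.8-fold lower number from compound 2 to compound 3 (0.58 log units; beyond the scatter). Among the compounds shown here, this is the first step that changes only one place, and it shows that the selenium and its nitrile can sit directly on the ring at this position without the longer chain, and that the number then falls by more than the usual scatter. No measurement available here explains why the number falls.

This single step removes the carbonyl, the amide nitrogen and the two-carbon stretch all at once, so it cannot show which of them goes with the higher number of compound 2. Still open, from the compounds shown here alone, is how a group of intermediate length would behave at this position, such as a selenium group joined to the ring through a single methylene, and how an amine or a carboxylic acid at the end of the chain would compare.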